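Series notes: acyl variation on the pyrrolidine amide

The compounds below may be only part of what the source reports. "The series", "measured", "known", "first", "only" and "open" are said of these compounds alone.

The common core carries a trifluoromethyl-bearing arylsulfonamide on a piperidine; the compounds differ only in the acyl group on the piperidine nitrogen. Compound 1 `O=C(Cn1ccnc1)N1CCC(NS(=O)(=O)c2cc(S(=O)(=O)c3ccccc3)ccc2C(F)(F)F)CC1` gives 230 nM in a functional assay on U2OS cells for antagonist activity at proto-oncogene Wnt-3 (Homo sapiens), read by a luciferase reporter, with a stated time of 18 h; on this read-out higher numbers stand for an effect only at larger amounts of compound and lower numbers for an effect already at smaller amounts. Compound 2 `CC(C)(C)C(=O)N1CCC[C@H]1C(=O)N1CCC(NS(=O)(=O)c2cc(S(=O)(=O)c3ccccc3)ccc2C(F)(F)F)CC1` gives 270 nM in the same assay, and the step of a 1.2-fold higher number from compound 1 to compound 2 (0.07 log units; within the scatter) shows that exchanging the whole acyl fragment left the read-out unchanged within scatter. Among the two measured compounds, compound 2 holds the higher number, though its gap to compound 1 does not exceed the scatter.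

Compound 3 `CN(C)CC(=O)N1CCC[C@H]1C(=O)N1CCC(NS(=O)(=O)c2cc(S(=O)(=O)c3ccccc3)ccc2C(F)(F)F)CC1` is the next variant. The change is (dimethylamino)methyl in place of tert-butyl on a carbonyl carbon. Among the measured compounds shown here, the only measured step that bears on it is a 1.2-fold higher number from compound 1 to compound 2 (0.07 log units; within the scatter), which stayed within the scatter. For compound 3 the expected step is therefore no change at the digits printed from compound 2 to compound 3 (within the scatter). For compound 3 the estimate in this assay is 270 nM, with a range of 120 nM to 650 nM.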

Compound 3, half-maximal effective concentration: 310 nM
Estimate against measurement, compound 3: 1.1-fold (0.06 log units) below, within the range that was stated.
By their numbers in this assay, from the lowest: compounds 1, 2 and 3 (each within the scatter of the next).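

Exchanging tert-butyl for (dimethylamino)methyl on the carbonyl carbon brings in a nitrogen and a hydrogen-bond acceptor at an unchanged heavy-atom count, and the result in this assay is a 1.1-fold higher number from compound 2 to compound 3 (0.06 log units; within the scatter), so this position accepts that exchange without a change beyond the scatter. Replacing the (1H-imidazol-1-yl)methyl group of compound 1 with the whole 1-(((dimethylamino)methyl)carbonyl)pyrrolidin-2-yl fragment gives a 1.3-fold higher number from compound 1 to compound 3 (0.13 log units; within the scatter), so this larger exchange also stays within the scatter. No supporting data accompany these values to explain the result.

Still open, on these data alone, is whether a carboxylic acid, a primary amine or a longer alkyl chain on this carbonyl carbon would move the number beyond the scatter. Also open, as far as these compounds go, is whether the same tolerance would hold on a different core.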